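Adding a Trifluoromethyl Group to the Strongest Compound

The source may hold more compounds than are shown below. What is called first, only, known or untested is meant among the compounds shown, and "the series" means these compounds.

A set of three compounds built on one shared core has been measured in an assay on isolated protein for inhibition of Leucine-rich repeat serine/threonine-protein kinase 2 (Homo sapiens), read by TR-FRET and LanthaScreen, with stated times of 50 min and 30 min, in the presence of a further agent that is not named here; a lower number here means a stronger inhibitor, a higher number a weaker inhibitor. Compound 1 `Cc1c(Nc2nc(N)c3c(C#N)c(N4CCC[C@H]4C)n(C)c3n2)cnn1C` gives 75 nM. Compound 2 `Cc1c(Nc2nc(N)c3c(C#N)c(N4CCC[C@H]4C)n(C)c3n2)cnn1C1COC1`, with an oxetan-3-yl in place of methyl on an aromatic nitrogen, gives 47 nM; the step of a 1.6-fold lower number from compound 1 to compound 2 (0.20 log units; within the scatter) stays within the scatter. Compound 3 `C[C@@H]1CCCN1c1c(C#N)c2c(N)nc(Nc3cnn(C)c3)nc2n1C` gives 6 nM, the lowest of the three numbers, and both a 13-fold lower number from compound 1 to compound 3 (1.10 log units; beyond the scatter) and a 7.8-fold lower number from compound 2 to compound 3 (0.89 log units; beyond the scatter) lie beyond the scatter, so compound 3 stands clearly apart as the strongest inhibitor here.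

Compound 4 `C[C@@H]1CCCN1c1c(C#N)c2c(N)nc(Nc3cn(C)nc3C(F)(F)F)nc2n1C` differs from compound 3 in one place: trifluoromethyl in place of hydrogen on an aromatic carbon. The step that bears on this change is a 13-fold lower number from compound 1 to compound 3 (1.10 log units; beyond the scatter), in which taking a methyl off an aromatic carbon of the same five-membered ring lowered the number strongly. A group entering on a carbon of that ring has thus been seen to raise the number, and the trifluoromethyl entering here is larger than the methyl that left there. Compound 4 is therefore expected to show a modest to large rise, a 6.7-fold higher number from compound 3 to compound 4 (0.82 log units; beyond the scatter), with an estimate of 40 nM and a likely range from 10 nM to 200 nM.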

Compound 4, half-maximal inhibitory concentration: 508 nM
The estimate for compound 4 lay 13-fold (1.10 log units) below the measured number, and the stated range ends below it.
By their numbers in this assay, from the lowest: compound 3; then compounds 2 and 1 (each within the scatter of the next); then compound 4.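

Trifluoromethyl on this carbon brings an 85-fold higher number from compound 3 to compound 4 (1.93 log units; beyond the scatter) and this is the largest step in the set, so a ring carbon that carries only hydrogen in compound 3 is also sensitive to change, not just the carbon bearing methyl in the 1,5-dimethyl-1H-pyrazol-4-yl group. The new group also does worse than the earlier substituted rings: 1-methyl-3-(trifluoromethyl)-1H-pyrazol-4-yl gives a 6.8-fold higher number from compound 1 to compound 4 (0.83 log units; beyond the scatter) against 1,5-dimethyl-1H-pyrazol-4-yl and an 11-fold higher number from compound 2 to compound 4 (1.03 log units; beyond the scatter) against 5-methyl-1-(oxetan-3-yl)-1H-pyrazol-4-yl. Among these four compounds, every group on a ring carbon goes with a higher number than hydrogen does in compound 3, and no compound goes against this.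

A methyl, a chlorine atom or an amine on this same carbon would show whether any group raises the number here or whether the rise belongs to trifluoromethyl itself. Nothing measured here gives the reason for the rise.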